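Phenol methylation across two amide-linked cores

The compounds below may be only part of what the source reports. "The series", "measured", "known", "first", "only" and "open" are said of these compounds alone.

Measured in a functional assay on ACHN cells (Homo sapiens) for inhibition, read by sulforhodamine B assay, with a stated time of 48 h, tested at 10 uM; a higher number here means a weaker effect of the compound at the concentration tested, a lower number a stronger effect:
compound 1 `O=C(Nc1cccc(-n2cc(-c3ccncc3)c(-c3cc(O)cc(Cl)c3)n2)c1)Nc1ccc(Cl)c(C(F)(F)F)c1` gives 21.3%
compound 2 `COc1cc(Cl)cc(-c2nn(-c3cccc(NC(=O)Nc4ccc(Cl)c(C(F)(F)F)c4)c3)cc2-c2ccncc2)c1` gives 8.78%
compound 3 `O=C(Nc1cccc(-n2cc(-c3ccncc3)c(-c3cc(O)cc(Cl)c3)n2)c1)c1cc(C(F)(F)F)cc(C(F)(F)F)c1` gives 37.7%

Compound 2 differs from compound 1 by methyl in place of hydrogen on an oxygen on an aromatic ring. This change gave a number 12.5 percentage points lower from compound 1 to compound 2 (beyond the scatter) in this assay. Compound 3 stands highest of the three measured numbers; the difference between the core of compound 3 and the core of compound 1 is not broken down here.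

Compound 4 `COc1cc(Cl)cc(-c2nn(-c3cccc(NC(=O)c4cc(C(F)(F)F)cc(C(F)(F)F)c4)c3)cc2-c2ccncc2)c1` is not yet measured. It differs from compound 3 by methyl in place of hydrogen on an oxygen on an aromatic ring, the same change as between compound 1 and compound 2, at a place described in the same words. Among the compounds shown this change occurs twice, once measured and once pending.

Because the measured instance gave a number 12.5 percentage points lower from compound 1 to compound 2 (beyond the scatter), a step of similar size and direction is expected here, so a number 12.7 percentage points lower from compound 3 to compound 4 (beyond the scatter) is the estimated step from compound 3 to compound 4 in this assay. Among the measured compounds shown here, with only one measured instance, the range is kept wide. Compound 4 is therefore expected to give about 25%, between 10% and 40%.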

Compound 4, a percentage reported as activity, at one concentration (the size of the read-out at that concentration, not a potency): 58.2%
Compound 4: middle estimate off by 33.2 percentage points, on the low side; the measured number lies above the stated range.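

In this assay, hydroxy to methoxy on the 3-chloro-5-hydroxyphenyl group gave a number 20.5 percentage points higher from compound 3 to compound 4 (beyond the scatter), so on this core the methoxy compound has the weaker effect at the concentration tested. The change therefore does not carry over from one core to the other in this series, and its direction depends on the core it sits on: the same change on two cores in this assay, a number 12.5 percentage points lower (beyond the scatter) from compound 1 to compound 2 and a number 20.5 percentage points higher (beyond the scatter) from compound 3 to compound 4, 33 percentage points apart, beyond the scatter of two such steps

Among the compounds shown here, with only two pairs, this does not show which structural difference between the two cores goes with the reversal, nor does it give a rule for predicting the step on a third core. The read-out is also a single-concentration percentage, so neither step says anything about potency.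

The compounds shown leave open how the two cores would respond to other groups in place of hydroxy and methoxy, such as an amine or a longer chain on the oxygen like ethoxy. They also leave open whether any such group would follow the split seen here.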